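The source may hold more compounds than are shown below. What is called first, only, known or untested is meant among the compounds shown, and "the series" means these compounds.

Working notes on the series. Compound 2 `COc1ccc(-c2cc(C(=O)c3ccccc3)c(N)s2)cc1` gives 31% in an assay on CHO cells for positive allosteric modulation of adenosine receptor A1 (Homo sapiens), read by ERK phosphorylation, tested at 3 uM; on this read-out higher numbers stand for a weaker effect at the one concentration tested and lower numbers for a stronger effect. It sits second highest of the three numbers: compound 1 `Nc1sc(-c2ccccc2)cc1C(=O)c1ccccc1` gives 12%, and the step of a number 19 percentage points higher from compound 1 to compound 2 (beyond the scatter) is beyond the scatter; compound 3 `Nc1sc(-c2ccc(C(=O)O)cc2)cc1C(=O)c1ccccc1` gives 51%, and the step of a number 20 percentage points higher from compound 2 to compound 3 (beyond the scatter) is also beyond the scatter. The widest gap in the set is a number 39 percentage points higher from compound 1 to compound 3 (beyond the scatter).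

Compound 4 `COc1ccc(-c2cc(C(=O)c3ccc(Cl)cc3)c(N)s2)cc1` differs from compound 2 by chloro in place of hydrogen on an aromatic carbon. All three measured steps concern the other six-membered ring, the one attached to the shared core, and none concerns the ring that carries the carbonyl. Among the measured compounds shown here, no measured step therefore bears directly on this change; the data only show that every substituent so far on the other ring raised the number, by a number 19 percentage points higher from compound 1 to compound 2 (beyond the scatter) and by a number 39 percentage points higher from compound 1 to compound 3 (beyond the scatter). For the present change the expected step is no step beyond the scatter, a number 4 percentage points higher from compound 2 to compound 4 (within the scatter), with a wide range. Compound 4 is estimated at 35%, between 15% and 60%.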

Compound 4, a percentage reported as activity, at one concentration (the size of the read-out at that concentration, not a potency): 51%
The estimate for compound 4 lay 16 percentage points below the measured number, and the stated range covers the measured number.
By their numbers in this assay, from the lowest: compound 1; then compound 2; then compounds 3 and 4 (each within the scatter of the next).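

The ring that carries the carbonyl is not silent in this assay: phenyl to 4-chlorophenyl gives a number 20 percentage points higher from compound 2 to compound 4 (beyond the scatter), the first step measured on this ring. The single chloro on an aromatic carbon, para to a large group, moves the number in the same direction as the substituents on the other ring, and none of the four compounds goes against this direction so far. Nothing at hand accounts for this rise.

Only chloro is shown on this ring, so it stays open whether the step belongs to chloro itself or would also appear with another group at the same place, such as an amine or a longer chain. On these data alone, whether chloro gives a similar step on compound 1, without the methoxy, also stays open.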